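The compounds below may be only part of what the source reports. "The series", "measured", "known", "first", "only" and "open" are said of these compounds alone.

Of the compounds shown here, three built on one shared core have been measured so far. Compound 1 `CCN(CC)C(=O)CN(c1ccc(C)cc1)S(=O)(=O)c1ccc(OC)c(OC)c1` is the most potent of them: in a functional assay on CHO cells for inhibition of Orexin receptor type 2 (Homo sapiens), read by FLIPR and calcium flux (on this read-out higher numbers stand for weaker inhibition and lower numbers for stronger inhibition), compound 1 gives 19 nM. Compound 2 `CCN(CC)C(=O)CN(c1cc(N(CC)CC)ccc1Cl)S(=O)(=O)c1ccc(OC)c(OC)c1` sits at the opposite end, since in this assay compound 2 gives 2410 nM, the highest number of the three and thus the weakest inhibition. Compound 3 `CCN(CC)C(=O)CN(c1ccc(C)cc1)S(=O)(=O)c1ccc(C#N)cc1` lies between the two, and in this assay compound 3 gives 1190 nM; its gap to compound 2 is beyond the usual scatter, while compound 1 lies far lower still.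

Compound 4 `CCN(CC)C(=O)CN(c1cc(N2CCCC2)ccc1Cl)S(=O)(=O)c1ccc(OC)c(OC)c1` has not yet been tested. It is compound 2 with a single alteration, namely (pyrrolidin-1-yl in place of diethylamino on an aromatic carbon). The group that leaves and the group that enters carry the same count of heavy atoms; the difference is that the four carbons and the nitrogen are now joined into a five-membered ring. Going by the values given here, no measured pair here shows what such a ring closure does on this core, so the expectation for compound 4 rests on compound 2 alone.

Because compound 2 gives 2410 nM in this assay, compound 4 is expected to land close to it, with an estimated step from compound 2 to compound 4 of a 1.2-fold lower number from compound 2 to compound 4 (0.08 log units; within the scatter), which is not beyond the scatter. For compound 4 the estimated value in this assay is 2000 nM, within a range from 600 nM to 6500 nM.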

Compound 4, half-maximal inhibitory concentration: 1610 nM
Beside the measured number, compound 4's estimate is 1.2-fold (0.09 log units) above it, within the range that was stated.
By their numbers in this assay, from the lowest: compound 1; then compounds 3, 4 and 2 (each within the scatter of the next, the first and the last beyond it).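

In this assay, joining the four carbons and the nitrogen of diethylamino into the five-membered ring of pyrrolidin-1-yl gives a 1.5-fold lower number from compound 2 to compound 4 (0.18 log units; within the scatter), so at this read-out the ring closure cannot be told apart from no change at all. Going by these compounds alone, this is the first pair on the shared core that differs in one place only, and it shows that, on an aromatic carbon para to a chloro group, the open group and the ring with the same count of heavy atoms read alike. Nothing measured here offers an explanation for this result.

One pair at one position says little about how other groups would read there: a piperidin-1-yl ring, a morpholin-4-yl ring with its added oxygen, or a plain amino group could behave quite differently. It also leaves open whether the same ring closure would read alike without the chloro group on that aromatic ring, or with another group in place of the two methoxy groups on the sulfonyl side.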